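A few compounds are considered here, and "the series" means these few. Any claim that something is new, unique, unknown or untested is made for them only; others in the source may bear on it.

Measured compounds:
Compound 1, `CC(=O)c1ccc(Nc2ccnc(SCC(=O)c3ccc(Br)cc3)n2)cc1`, gives 44% in a functional assay on T47D cells (Homo sapiens) for inhibition, read by sulforhodamine B assay, with a stated time of 48 h, tested at 10 uM; a higher number here means more inhibition of growth at the concentration tested, a lower number less inhibition of growth.
Compound 2, `CC(=O)c1cccc(Nc2ccnc(SCC(=O)c3ccc(-c4ccccc4)cc3)n2)c1`, gives 49% in this assay.
Compound 3, `CC(=O)c1ccc(Nc2ccnc(SCC(=O)c3ccc(Cl)cc3)n2)cc1`, gives 71% in this assay.

Compound 3 stands highest of the three numbers in this assay; its nearest neighbour is compound 2, and compound 1 lies furthest from it, both gaps being beyond the scatter. Compound 4, `CC(=O)c1ccc(Nc2ccnc(SCC(=O)c3ccc(-c4ccccc4)cc3)n2)cc1`, differs from compound 3 in one place: phenyl in place of chloro on an aromatic carbon.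

Within the data shown here, only one measured step changes that same position: a number 27 percentage points higher from compound 1 to compound 3 (beyond the scatter). That step swaps one halogen for another and is modest; it does not show what happens when a ring enters in place of a halogen. Compound 2 carries the same phenyl group as compound 4 but with the acetyl on a different carbon of the anilino ring, and in this assay compound 2 gives 49%, which sits below compound 3. Among the measured compounds shown here, no measured step connects compound 2 to compound 4, so it can only serve as a loose pointer. On this basis the expected step of a number 19 percentage points lower from compound 3 to compound 4 (beyond the scatter) is a moderate fall in this assay, with wide uncertainty. Compound 4 is therefore estimated at 52% in this assay, within a range from 30% to 74%.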

Compound 4, percent growth inhibition at one concentration: 29%
The estimate for compound 4 lay 23 percentage points above the measured number; measured number below the stated range.
By their numbers in this assay, from the lowest: compound 4; then compounds 1 and 2 (each within the scatter of the next); then compound 3.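

Within this assay, phenyl in place of chloro on this aromatic carbon brings a number 42 percentage points lower from compound 3 to compound 4 (beyond the scatter) and is a large step, so a ring entering here has a much greater effect than the earlier swap of one halogen for another. Phenyl also falls short of bromo at the same carbon, with a number 15 percentage points lower from compound 1 to compound 4 (beyond the scatter) as a modest step, which gives an order of chloro, then bromo, then phenyl across compound 3, compound 1 and compound 4, with each gap beyond the scatter. With phenyl in place, the position of the acetyl also counts: 4-acetylphenyl in place of 3-acetylphenyl on the nitrogen brings a number 20 percentage points lower from compound 2 to compound 4 (beyond the scatter) and leaves compound 4 the lowest of the four.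

Nothing available explains why these numbers fall as they do. From the compounds shown here alone, it remains open whether a smaller group such as fluoro, or a group such as methoxy or an amine, would stand nearer chloro or nearer phenyl at this carbon, and whether moving the acetyl would shift the number in the same way with chloro in place of phenyl.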